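Chloro for methoxy in the (4-methoxyphenyl)amino group

The compounds below may be only part of what the source reports. "The series", "measured", "known", "first", "only" and "open" are said of these compounds alone.

Measured compounds in a functional assay on HepG2 cells (Homo sapiens) for cytotoxicity, with a stated time of 72 h; a higher number here means that more compound is needed for the effect, a lower number that less compound is needed:
- compound 1, `C=C[C@@](C)(/C=C/c1ccc(O)c(/C=C/c2ccc(F)cc2)c1)CCC=C(C)C`: compound 1 gives > 52000 nM, a limit of the assay and not a number.
- compound 2, `COc1ccc(/C=C/[C@@](C)(/C=C/c2ccc(O)cc2)CCC=C(C)C)cc1`: compound 2 gives > 52000 nM, again a limit and not a number.
- compound 3, `C=C[C@@](C)(/C=C/c1ccc(Nc2ccc(OC)cc2)cc1)CCC=C(C)C`: compound 3 gives > 52000 nM, also a limit and not a number.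

Where compound 3 stands: every value shown is the limit of > 52000 nM in this assay, at which 3 of the 3 values shown sit, so compound 3 sits where compound 1 and compound 2 also sit, and no ordering among the three can be read from these numbers. Within the data shown here, no pair of measured compounds differs in one place only, so no measured step is available in this assay.

Compound 4 is `C=C[C@@](C)(/C=C/c1ccc(Nc2ccc(Cl)cc2)cc1)CCC=C(C)C`. Relative to compound 3 the change is chloro in place of methoxy on an aromatic carbon.

With compound 3 at a limit and nothing measured to size the effect of this change, the step from compound 3 to compound 4 in this assay is expected to be a step that the limit leaves unreadable from compound 3 to compound 4, that is, none beyond the scatter. Compound 4 is therefore expected to give about 60000 nM in this assay, with a range of 25000 nM to 150000 nM, and most probably the assay will again report only a limit.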

Compound 4, half-maximal effective concentration: > 52000 nM
Compound 4: no number, only a limit (the forecaster's own chance of this, stated with the estimate: 80%); the middle value lies beyond the limit too.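

In this assay, no step can be read from compound 3 to compound 4, because both give only a limit and not a number: the limit of > 52000 nM in this assay, at which 4 of the 4 values shown sit.

The compounds shown leave open how chloro and methoxy compare at this aromatic carbon, and which structural change, if any, would give a measurable value in this assay.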